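A few compounds are considered here, and "the series" means these few. Any claim that something is new, unique, unknown or untested is made for them only; others in the source may bear on it.

Measured so far in a physicochemical assay for solubility; on this read-out lower numbers stand for lower solubility and higher numbers for higher solubility:
- compound 1 `Cc1nc(-c2cc(C(F)(F)F)ccc2[C@@H]2CCOc3cc(S(=O)(=O)Nc4nccs4)ccc32)co1` gives 130000 nM
- compound 2 `Cn1nccc1-c1cc(C(F)(F)F)ccc1[C@H]1CCOc2cc(S(=O)(=O)Nc3nccs3)ccc21` gives 83000 nM

Compound 2 stands within the scatter of compound 1, so these two numbers do not separate. Compound 3 `Cn1nccc1-c1cc(C(F)(F)F)ccc1[C@@H]1CCOc2cc(S(=O)(=O)Nc3nccs3)ccc21` is still unmeasured and carries one change from compound 2: the two compounds have the same atoms and bonds and differ only in configuration as drawn: 1 of 1 stereo elements differ; a stereocentre at a saturated ring carbon is drawn R in compound 2 and S in compound 3 and nothing more. Within the data shown here, the two compounds have the same atoms and bonds, and no measured pair here isolates such a change. In this assay no step beyond the scatter is expected, in either direction. The estimated step is a 1.0-fold higher number from compound 2 to compound 3 (0.01 log units; within the scatter) and stays inside the scatter. Compound 3 is estimated at 85000 nM with an expected range from 45000 nM to 160000 nM on this reading.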

Compound 3, solubility: 65000 nM
For compound 3 the middle estimate is 1.3-fold (0.12 log units) above the measured one; measured number inside the range.
By their numbers in this assay, from the lowest: compounds 3, 2 and 1 (each within the scatter of the next).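

In this assay, among these compounds, moving the stereocentre at the saturated ring carbon from R to S gives a 1.3-fold lower number from compound 2 to compound 3 (0.11 log units; within the scatter), so this pair offers the first direct reading of configuration, and it does not separate the two forms. The comparison isolates that single element: the fact that compounds 2 and 3 differ only in the configuration as drawn. With 1-methyl-1H-pyrazol-5-yl in place of 2-methyl-1,3-oxazol-4-yl on an aromatic carbon, the result is a 2.0-fold lower number from compound 1 to compound 3 (0.30 log units; within the scatter), so that exchange does not separate the compounds either.

Going by these compounds, whether configuration reads the same with 2-methyl-1,3-oxazol-4-yl in place stays open. So does whether an amine or a carboxylic acid on that aromatic carbon would give a step beyond the scatter.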